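Thiosemicarbazone series on prostate carcinoma cells: arylidene swap

The source may report more compounds than this note shows. Statements on the series, on what has been measured and on what is new or still open speak of the compounds shown alone.

Working notes on a short series of thiosemicarbazides and their arylidene derivatives, all carrying the same terpene-derived core. The unsubstituted hydrazine compound 1 `CC1=CC[C@H](C(C)(C)NC(=S)NN)CC1` and its arylidene derivative compound 2 `CC1=CC[C@H](C(C)(C)NC(=S)N/N=C/c2ccc(Cl)cc2)CC1` have both been measured in a functional assay on PC-3 cells (Homo sapiens) for inhibition, read by sulforhodamine B assay, with a stated time of 48 h; on this read-out lower numbers stand for stronger inhibition of growth and higher numbers for weaker inhibition of growth. Compound 1 gives 44500 nM in this assay. Going by the values given here, compound 2 gives 50 nM in this assay, which is the lower of the two numbers measured so far; the gap to compound 1 lies far beyond the scatter of repeated measurements.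

Compound 3 `CC1=CC[C@H](C(C)(C)NC(=S)N/N=C/c2ccco2)CC1` remains to be measured. Relative to compound 2 it differs in one place: furan-2-yl in place of 4-chlorophenyl on a carbon with a double bond to nitrogen. Among the compounds with values here, no measured pair in this set isolates this kind of aromatic exchange, so the expectation rests on compound 2 alone. A modest step is expected from compound 2 to compound 3 in this assay, towards a higher number, of the order of a 3.0-fold higher number from compound 2 to compound 3 (0.48 log units; beyond the scatter), which may still fall within the scatter. The estimate for compound 3 in this assay is 150 nM, with a range from 40 nM to 600 nM.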

Compound 3, concentration for 50% growth inhibition: 13500 nM
Estimate against measurement, compound 3: 90-fold (1.95 log units) below, outside the stated range (above it).
By their numbers in this assay, from the lowest: compound 2; then compound 3; then compound 1.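

In this assay, the exchange of 4-chlorophenyl for furan-2-yl on a carbon with a double bond to nitrogen gives a 270-fold higher number from compound 2 to compound 3 (2.43 log units; beyond the scatter), so this position is highly sensitive to which aromatic group it carries, and the presence of an aromatic ring alone does not secure a low number. The furan-2-yl arylidene still retains a measurable advantage over the unsubstituted hydrazine, with a 3.3-fold lower number from compound 1 to compound 3 (0.52 log units; beyond the scatter), a modest step beside the large one produced by the aromatic exchange. No supporting data bear on why the exchange has so large an effect.

The exchange changes the ring size, the ring hetero atom and the chlorine together, so the compounds shown cannot assign the large step to any one of these differences. Plain phenyl would isolate the contribution of the chlorine, while 5-chlorofuran-2-yl would test the furan ring with a chlorine retained.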